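A Silicon-for-Carbon Swap in a Weakly Active Series

The source may hold more compounds than are shown below. What is called first, only, known or untested is meant among the compounds shown, and "the series" means these compounds.

Compound 1 `CC(C)(C)c1cn(C[C@H](O)[C@H]2OC(=O)C(OCc3ccccc3)=C2OCc2ccccc2)nn1`: 54900 nM
Compound 2 `O=C1O/C(=C\Cn2cc(-c3cc(F)cc(F)c3)nn2)C(OCc2ccccc2)=C1OCc1ccccc1`: "not active" (no number reported)
Compound 3 `Cc1ccc(-c2cn(C/C=C3\OC(=O)C(OCc4ccccc4)=C3OCc3ccccc3)nn2)cc1`: > 100000 nM

Within the data shown here, in a functional assay on CFPAC-1 cells (Homo sapiens) for antiproliferative activity, read by MTT assay, with a stated time of 72 h (on this read-out higher numbers stand for weaker inhibition and lower numbers for stronger inhibition), compound 1 gives 54900 nM, the only single number among the three entries. Compound 2 is reported simply as "not active" (no number reported). For compound 3 the value > 100000 nM is a limit of the assay rather than a number, as noted by the limit of > 100000 nM in this assay, at which 1 of the 3 values shown sits. Among the measured compounds shown here, compound 1 therefore stands alone as the one compound with a measured concentration. Compound 4 `C[Si](C)(C)c1cn(C[C@H](O)[C@H]2OC(=O)C(OCc3ccccc3)=C2OCc2ccccc2)nn1` differs from it by a group of 4 heavy atoms (3 carbon, 1 silicon; no ring) in place of a group of 4 heavy atoms (4 carbon; no ring), on an aromatic carbon. For the measured compounds named here, no measured pair differing in a single place exists here, so the step has no precedent in this set. The two groups match in heavy-atom count, donors, acceptors and charge, and the expected step of a 1.1-fold lower number from compound 1 to compound 4 (0.04 log units; within the scatter) lies within the scatter. Compound 4 is expected to give 50000 nM, between 20000 nM and 120000 nM.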

Compound 4, half-maximal inhibitory concentration: 52600 nM
Beside the measured number, compound 4's estimate is 1.1-fold (0.02 log units) below it; the range from low to high includes it.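

With the silicon-bearing group in place of tert-butyl on the aromatic carbon, the set gains its first readable step in this assay, a 1.0-fold lower number from compound 1 to compound 4 (0.02 log units; within the scatter). This position therefore tolerates the exchange of carbon for silicon at the centre of the group, and the read-out stays in the same weak range. Nothing measured here accounts for this result. As far as these compounds go, it remains open whether an amine, a carboxylic acid or a longer chain on this aromatic carbon would move the number beyond the scatter. From the compounds shown here alone, whether the swap reads alike in other cell lines also remains open.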